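The source may report more compounds than this note shows. Statements on the series, on what has been measured and on what is new or still open speak of the compounds shown alone.

Measured so far:
compound 1 `OCCCCNc1nnc(-c2ccc(F)c(F)c2Nc2ccc(I)cc2F)o1` — < 3 ug/mL
compound 2 `OCCNc1nnc(-c2ccc(F)c(F)c2Nc2ccc(I)cc2F)o1` — < 3 ug/mL

In a physicochemical assay for solubility, read by HPLC, in phosphate buffer, at pH 6.5 (a higher number here means a more soluble compound, a lower number a less soluble compound), compound 1 gives only a limit, < 3 ug/mL. In this assay compound 2 likewise gives only a limit, < 3 ug/mL. Among the compounds with values here, the single measured step, a step that the two limits leave unreadable from compound 1 to compound 2, is therefore not readable in size or direction, and compound 2 cannot be placed on a number: it sits at the limit of < 3 ug/mL in this assay, at which 2 of the 2 values shown sit.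

Compound 3 `CCN(CC)CCCNc1nnc(-c2ccc(F)c(F)c2Nc2ccc(I)cc2F)o1` differs from compound 2 by (diethylamino)methyl in place of hydroxy on a saturated chain carbon, two bonds along the chain from a nitrogen on an aromatic ring. Within the data shown here, no measured step bears on this change, and the one step that exists between the measured compounds tells nothing because the limit of < 3 ug/mL in this assay, at which 2 of the 2 values shown sit, hides both ends. The expectation for this assay rests on the change alone and is held wide. The step expected is an at least 6.6-fold higher number from compound 2 to compound 3 (0.82 log units; beyond the scatter), in the direction of higher solubility. Compound 3 is expected to give about 20 ug/mL, with a range from 3 ug/mL to 150 ug/mL, and a real chance that only a limit is again reported.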

Compound 3, solubility: < 3 ug/mL
Compound 3: no number, only a limit; the forecaster's own chance of this, stated with the estimate: 20%; middle value at least 6.6-fold (0.82 log units) away from the limit.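

In this assay compound 3 gives only a limit, < 3 ug/mL. No step among compound 1, compound 2 and compound 3 can be read, in size or in direction: the limit of < 3 ug/mL in this assay, at which 3 of the 3 values shown sit.

Left open is whether these three compounds differ at all in this assay, and if so, in what order.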